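The compounds below may be only part of what the source reports. "The series", "measured", "known", "first", "only" and "open" are said of these compounds alone.

Compound 1 `COc1cc(NC(C)CCCN2C(=O)CN(C(=O)[C@@H](C)N)C2(C)C)c2ncccc2c1` carries a methyl on a saturated chain carbon bound to an amine nitrogen and a carbonyl carbon; in an ADME assay on A549 cells (Homo sapiens) for cytotoxicity, with a stated time of 72 h (on this read-out lower numbers stand for stronger inhibition and higher numbers for weaker inhibition), compound 1 gives 7800 nM. Compound 2 `COc1cc(NC(C)CCCN2C(=O)CN(C(=O)CN)C2(C)C)c2ncccc2c1` lacks that methyl. In this assay compound 2 reaches only a limit of the measurement, > 100000 nM, and no number. Where compound 2 stands is told by the limit of > 100000 nM in this assay, at which 1 of the 2 values shown sits. Among the measured compounds shown here, the one measured step, an at least 12-fold higher number from compound 1 to compound 2 (1.10 log units; beyond the scatter), thus shows that taking the methyl away costs a large amount of inhibitory strength. Compound 3 `CC[C@H](C)[C@@H](N)C(=O)N1CC(=O)N(CCCC(C)Nc2cc(OC)cc3cccnc23)C1(C)C` moves the other way from compound 2: sec-butyl in place of hydrogen on a saturated chain carbon bound to an amine nitrogen and a carbonyl carbon. Because an at least 12-fold higher number from compound 1 to compound 2 (1.10 log units; beyond the scatter) was recorded on removing an alkyl group from this very carbon, putting a larger alkyl group back is expected to push the number down again, toward or past the level of compound 1. Compound 3 is therefore expected to give about 5000 nM in this assay, within a range from 1500 nM to 30000 nM. The estimated step is an at least 20-fold lower number from compound 2 to compound 3 (1.30 log units; beyond the scatter).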

Compound 3, half-maximal inhibitory concentration in the A549 assay: 14900 nM
Beside the measured number, compound 3's estimate is 3.0-fold (0.47 log units) below it, within the range that was stated.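

In the A549 assay compound 2 stands at > 100000 nM, which is a limit of the measurement and not a number. Measured against that limit, sec-butyl on the saturated chain carbon bound to an amine nitrogen and a carbonyl carbon gives an at least 6.7-fold lower number from compound 2 to compound 3 (0.82 log units; beyond the scatter), so in the compounds shown a second alkyl group, and not only methyl, goes with a lower number than hydrogen at this place. Sec-butyl in place of methyl gives a 1.9-fold higher number from compound 1 to compound 3 (0.28 log units; within the scatter), so the A549 assay does not tell these two alkyl groups apart, while the change from hydrogen to sec-butyl also lowers the number in a physicochemical assay for solubility; on this read-out lower numbers stand for lower solubility and higher numbers for higher solubility: the measured solubility of compound 2, 150000 ug/mL, and of compound 3, 29700 ug/mL, a 5.1-fold lower number (0.70 log units; beyond the scatter)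

In the physicochemical assay compound 2 gives 150000 ug/mL and compound 3 gives 29700 ug/mL. The compounds shown leave open whether a group of another kind on this carbon, such as a benzyl group or a carboxylic acid, would take the number in the A549 assay clearly past the level shared by compound 1 and compound 3. Where methyl would fall between hydrogen and sec-butyl in the physicochemical assay also remains open.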